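The source may report more compounds than this note shows. Statements on the series, on what has been measured and on what is new or still open speak of the compounds shown alone.

Of the compounds shown here, three of one family have been measured in a functional assay on NCI-H23 cells (Homo sapiens) for cytotoxicity, read by sulforhodamine B assay, with a stated time of 48 h; a higher number here means a weaker inhibitor of growth, a lower number a stronger inhibitor of growth. Compound 1 `Nc1nc(Cl)c2ncn(Cc3ccccc3CCl)c2n1` gives 8910 nM. Compound 2 `Nc1nc(Cl)c2ncn(Cc3ccc(CCl)cc3)c2n1` gives 30200 nM. Compound 3 `ClCc1ccccc1Cn1cnc2nc(Cl)nc(Cl)c21` gives 40700 nM, the highest number of the three; its number and that of compound 2 lie within the usual scatter of each other, so the two cannot be told apart, while compound 1 sits clearly lower, beyond the scatter.

The next compound, compound 4 `ClCc1ccccc1Cn1cnc2ncnc(Cl)c21`, has not yet been measured. It differs from compound 3 in a single way: hydrogen in place of chloro on an aromatic carbon. For the measured compounds named here, no measured pair in this set shows the effect of exactly this change, so there is no direct guide. Going by the values given here, with compound 3 already at the weak end and only one point of comparison, the step from compound 3 to compound 4 is expected to be small, in either direction, and probably not beyond the scatter: a 1.0-fold lower number from compound 3 to compound 4 (0.01 log units; within the scatter). On that basis compound 4 is estimated to give about 40000 nM in this assay, most likely between 15000 nM and 100000 nM.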

Compound 4, concentration for total growth inhibition: 17400 nM
Beside the measured number, compound 4's estimate is 2.3-fold (0.36 log units) above it, and the stated range covers the measured number.
By their numbers in this assay, from the lowest: compounds 1, 4, 2 and 3 (each within the scatter of the next, the first and the last beyond it).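

In this assay, for the compounds shown here, hydrogen in place of chloro on the aromatic carbon between two ring nitrogen atoms gives a 2.3-fold lower number from compound 3 to compound 4 (0.37 log units; beyond the scatter), the first change in this set that can be read in a single place. It shows that this chloro group is not needed for growth inhibition here, since the number falls once the chloro group has gone, though the step is a modest one. Nothing at hand accounts for this shift.

As far as these compounds go, it remains open whether a fluoro, methyl or methoxy group on the same carbon would give a number closer to that of compound 3 or that of compound 4. Also open, from the compounds shown here alone, is whether the same exchange gives a step of similar size on other members of the family, where the chloromethyl group sits elsewhere on the benzene ring.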